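From thiophen-2-yl to iodo on the methyl compound

The compounds below may be only part of what the source reports. "The series", "measured", "known", "first", "only" and "open" are said of these compounds alone.

In a functional assay on HepG2 cells (Homo sapiens) for antiproliferative activity, read by XTT assay, with a stated time of 72 h (a lower number here means a stronger inhibitor, a higher number a weaker inhibitor), compound 1 `Nc1nc(N)c2c(-c3cccs3)cn([C@@H]3O[C@H](CO)[C@@H](O)[C@H]3O)c2n1` gives > 20000 nM, which is a limit and not a number. Compound 2 `Cc1nc(N)c2c(-c3cccs3)cn([C@@H]3O[C@H](CO)[C@@H](O)[C@H]3O)c2n1` gives > 20000 nM, which is also a limit. Compound 2 therefore has no readable position in the series, and the whole picture so far is the limit of > 20000 nM in this assay, at which 2 of the 2 values shown sit.

Among the measured compounds shown here, the only measured step is a step that the two limits leave unreadable from compound 1 to compound 2. It supplies no size to carry forward, and it concerns a different place on the shared core from the one changed next.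

Compound 3 `Cc1nc(N)c2c(I)cn([C@@H]3O[C@H](CO)[C@@H](O)[C@H]3O)c2n1` keeps the methyl group of compound 2 and changes one substituent: iodo in place of thiophen-2-yl on an aromatic carbon. For the measured compounds named here, both measured compounds carry thiophen-2-yl, so no measured step shows what replacing this group does, and the expectation is loose. The most likely result is another limit, with no readable step. If a number does appear, it is expected on the stronger side in this assay. The estimated change is an at least 1.3-fold lower number from compound 2 to compound 3 (0.12 log units; that floor lies within the scatter). For compound 3 the estimate is 15000 nM, with an expected range of 3000 nM to 40000 nM.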

Compound 3, half-maximal inhibitory concentration: 6310 nM
Beside the measured number, compound 3's estimate is 2.4-fold (0.38 log units) above it; the range from low to high includes it.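

Iodo in place of thiophen-2-yl on this aromatic carbon gives an at least 3.1-fold lower number from compound 2 to compound 3 (0.50 log units; beyond the scatter) in this assay, so this position, two ring bonds from the ring nitrogen, can shift the antiproliferative read-out, and the methyl compound is not confined to the limit. The size is only a floor, as compound 2 gives a limit and not a number, and the step from compound 1 to compound 2 cannot be read. Compound 3 is the only compound shown with a number, while the other two remain at the limit: the limit of > 20000 nM in this assay, at which 2 of the 3 values shown sit.

From the compounds shown here alone, the pair cannot separate an effect of iodo itself from the loss of thiophen-2-yl, and it remains open whether a smaller halogen such as bromo or chloro, a phenyl ring, or an ethynyl group at this position would give a number near that of compound 3 or return to the limit. Also open, going by these compounds, is how amino in place of methyl would read with iodo at this position, a comparison that could give the other place on the shared core its first readable step.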